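The compounds below may be only part of what the source reports. "The series", "measured", "known", "first", "only" and "open" are said of these compounds alone.

In a functional assay on CCRF-CEM cells (Homo sapiens) (a higher number here means a weaker inhibitor, a lower number a stronger inhibitor), compound 1 `Nc1ncnc2c1ncn2C[C@@H]1C[C@H](CO)c2ccccc21` gives 24 ug/mL and stands highest of the three measured compounds, which makes it the weakest inhibitor among them. Compound 2 `Cc1ccc(-c2ncnc3c2ncn3C[C@@H]2C[C@H](CO)c3ccccc32)cc1` gives 1.4 ug/mL and shares the core of compound 1, while compound 3 `Cn1ncc2c1[C@@H](CO[Si](c1ccccc1)(c1ccccc1)C(C)(C)C)C[C@H]2Cn1cnc2c(O)ncnc21` gives 3.2 ug/mL on a different core. Compound 4 `CCOc1ncnc2c1ncn2C[C@@H]1C[C@H](CO)c2ccccc21` keeps the core of compound 1 and changes one group, with ethoxy in place of amino on an aromatic carbon. Among the measured compounds shown here, the only measured step at this place is a 17-fold lower number from compound 1 to compound 2 (1.23 log units; beyond the scatter) with 4-methylphenyl in place of amino, a large change beyond the scatter. For the measured compounds named here, no measured compound carries ethoxy, so this single step hints at a direction but does not fix a size. A step in the same direction but smaller is therefore expected, and the estimated step is a 3.4-fold lower number from compound 1 to compound 4 (0.54 log units; beyond the scatter) on present evidence. The estimate for compound 4 is 7 ug/mL with an expected range from 2.5 ug/mL to 20 ug/mL in this assay when it is measured.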

Compound 4, half-maximal inhibitory concentration: 24 ug/mL
Estimate against measurement, compound 4: 3.4-fold (0.54 log units) below; the measured number lies above the stated range.
By their numbers in this assay, from the lowest: compound 2; then compound 3; then compounds 1 and 4 (each within the scatter of the next).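

In this assay, the change to ethoxy on this aromatic carbon gives no change at the digits printed from compound 1 to compound 4 (within the scatter), so taking away amino is not by itself enough to lower the number at this position. The comparison of the two replacements gives a 17-fold higher number from compound 2 to compound 4 (1.23 log units; beyond the scatter), which shows that the outcome depends strongly on which group enters here, and that the lower number of compound 2 does not extend to ethoxy. No available evidence bears on why these two groups differ so widely. The compounds shown leave open whether an unsubstituted phenyl ring or a 4-methoxyphenyl group at this carbon would track compound 2, and whether a smaller group such as methoxy would track compound 4. They also leave open whether a longer chain, such as butoxy, would lower the number.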